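The source may report more compounds than this note shows. Statements on the series, on what has been measured and on what is new or still open speak of the compounds shown alone.

In an ADME assay on MDBK cells (Bos taurus) for cytotoxicity (a higher number here means that more compound is tolerated, a lower number that less compound is tolerated), compound 3 (`Clc1cccc(Cn2ccc3nc(-c4ccccc4)nc-3c2)c1`) gives > 100000 nM, which is a limit of the assay and not a number. Compound 1 (`Fc1cccc(F)c1Cn1ccc2nc(-c3ccccc3)nc-2c1`) gives > 100000 nM, also a limit. Compound 2 (`Fc1ccccc1Cn1ccc2nc(-c3ccccc3)nc-2c1`) gives > 100000 nM, again a limit. Compound 3 therefore has no numerical position in the series, and the three results together amount to the limit of > 100000 nM in this assay, at which 3 of the 3 values shown sit.

The next change leads to compound 4 (`Brc1cccc(Cn2ccc3nc(-c4ccccc4)nc-3c2)c1`), with bromo in place of chloro on an aromatic carbon, meta to a large group: bromo in place of chloro on an aromatic carbon. The same difference reads as 3-chlorophenyl to 3-bromophenyl.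

Within the data shown here, three measured steps bear on this change: a step that the two limits leave unreadable from compound 1 to compound 2, a step that the two limits leave unreadable from compound 1 to compound 3 and a step that the two limits leave unreadable from compound 2 to compound 3. None of them has a readable size, and none exchanges chloro for bromo, so the series provides no measured size for this change.

With compound 3 at > 100000 nM, a limit, no step beyond the scatter is expected in this assay, and a further limit is the likely report for compound 4. The expected change is a number no higher from compound 3 to compound 4 (the limit leaves the size open). Compound 4 is estimated at 100000 nM, with an expected range from 50000 nM to 200000 nM.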

Compound 4, half-maximal cytotoxic concentration: 85000 nM
Compound 4: the middle estimate sits 1.2-fold (0.07 log units) above what was measured; the measured number falls inside the stated range.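

In this assay, among these compounds, compound 4 gives 85000 nM, the only value so far that is a number and not a limit. Bromo in place of chloro on an aromatic carbon, meta to a large group, therefore gives the first readable step at this position, an at least 1.1-fold lower number from compound 3 to compound 4 (0.07 log units; that floor lies within the scatter), and the two wider comparisons read alike: an at least 1.1-fold lower number from compound 2 to compound 4 (0.07 log units; that floor lies within the scatter), and an at least 1.1-fold lower number from compound 1 to compound 4 (0.07 log units; that floor lies within the scatter). All three are floors within the scatter, so the 3-bromophenyl result shows no step beyond it, and the series still stands largely at one limit: the limit of > 100000 nM in this assay, at which 3 of the 4 values shown sit.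

Going by these compounds, the steps among compounds 1, 2 and 3 cannot be read, and the true size of the three new steps stays open, as each rests on a limit at one end. Also open, on these data alone, is whether an amine, a carboxylic acid or a methoxy group in place of bromo on this aromatic carbon would give a number clearly separated from that of compound 4, and whether any change to the shared core would do so.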